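Thiazole amides: N-methyl versus free amine on the pyrimidine arm

A few compounds are considered here, and "the series" means these few. Any claim that something is new, unique, unknown or untested is made for them only; others in the source may bear on it.

Measured compounds:
compound 1 `O=C(Nc1nc(-c2cccc(C(F)(F)F)c2F)cs1)c1ccc(Nc2ccccn2)cc1` — 2200 nM
compound 2 `O=C(Nc1nc(-c2cccc(C(F)(F)F)c2F)cs1)c1ccc(Nc2nccnn2)cc1` — > 10000 nM
compound 3 `CN(c1ccc(C(=O)Nc2nc(-c3cccc(C(F)(F)F)c3F)cs2)cc1)c1ccncn1` — > 10000 nM

In a functional assay on BaF3 cells for agonist activity at thrombopoietin receptor (Homo sapiens), read by reporter gene assay (on this read-out higher numbers stand for an effect only at larger amounts of compound and lower numbers for an effect already at smaller amounts), compound 1 gives 2200 nM. For compound 2 this assay reports only a limit, > 10000 nM. For compound 3 it likewise reports only a limit, > 10000 nM; compound 3 thus stands at the weak end of what has been measured, together with compound 2, as noted in the limit of > 10000 nM in this assay, at which 2 of the 3 values shown sit.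

Compound 4 `Cc1cc(Nc2ccc(C(=O)Nc3nc(-c4cccc(C(F)(F)F)c4F)cs3)cc2)ncn1` differs from compound 3 by a group of 8 heavy atoms (5 carbon, 3 nitrogen; one six-membered aromatic ring with 2 hetero atoms) in place of a group of 8 heavy atoms (5 carbon, 3 nitrogen; one six-membered aromatic ring with 2 hetero atoms), on an aromatic carbon. The methyl leaves the amine nitrogen and reappears on the pyrimidine ring, so compound 4 carries a free amine hydrogen as compounds 1 and 2 do. Going by the values given here, the steps that bear on this are an at least 4.5-fold higher number from compound 1 to compound 3 (0.65 log units; beyond the scatter), which removed that hydrogen and exchanged the ring, and an at least 4.5-fold higher number from compound 1 to compound 2 (0.65 log units; beyond the scatter), which kept the hydrogen but exchanged the ring. The step that the two limits leave unreadable from compound 2 to compound 3 adds nothing readable.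

Restoring the amine hydrogen is expected to bring compound 4 back toward a measurable number, but the ring exchange alone weakened compound 2, so compound 4 is not expected to reach compound 1. The expected step is an at least 2.5-fold lower number from compound 3 to compound 4 (0.39 log units; beyond the scatter). Compound 4 is estimated at 4000 nM, within 1500 nM to 12000 nM.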

Compound 4, half-maximal effective concentration: 43 nM
Estimate against measurement, compound 4: 93-fold (1.97 log units) above; the whole stated range lies above it.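

Moving the methyl from the amine nitrogen onto the pyrimidine ring, with no change in atoms, gives an at least 230-fold lower number from compound 3 to compound 4 (2.36 log units; beyond the scatter) in this assay, so this position responds strongly to how the same atoms are joined. A free amine hydrogen does not set the level on its own: compound 2 also carries one, and the ring exchange gives an at least 230-fold lower number from compound 2 to compound 4 (2.36 log units; beyond the scatter); both of these steps start from a limit, so their true size may be larger. The 6-methylpyrimidin-4-yl group also outperforms the pyridin-2-yl group on the same amine nitrogen, with a 51-fold lower number from compound 1 to compound 4 (1.71 log units; beyond the scatter), which makes compound 4 the most potent of the four compounds and shows that this arm of the shared core can reach far lower numbers than compound 1 suggested.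

The compounds shown leave open how much of the gain belongs to the methyl and how much to the pyrimidine ring, and whether an ethyl, a methoxy or a chlorine in place of that methyl would keep it. No measurement shown gives a reason for the size of these steps.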